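Swapping a Methyl for an Aryl Group on a Ring Nitrogen

The compounds below may be only part of what the source reports. "The series", "measured", "known", "first", "only" and "open" are said of these compounds alone.

Three compounds share one core and differ only in the group attached to an amine nitrogen in a ring. Compound 1 `O=C1NC(c2ccccc2)(c2ccccc2)C(=O)N1CN1CCN(c2ccccc2)CC1` carries a phenyl there, compound 2 `O=C1NC(c2ccccc2)(c2ccccc2)C(=O)N1CN1CCN(c2ccc(F)cc2)CC1` a 4-fluorophenyl, and compound 3 `CN1CCN(CN2C(=O)NC(c3ccccc3)(c3ccccc3)C2=O)CC1` a methyl. In a functional assay on the whole organism (strain CD1) with Mus musculus as the target, in the maximal electroshock model, with a stated time of 4 h (on this read-out higher numbers stand for an effect only at larger amounts of compound and lower numbers for an effect already at smaller amounts), compound 1 gives 100 mg/kg, compound 2 gives 100 mg/kg, and compound 3 gives 10 mg/kg, which is the lowest of the three numbers, the other two standing well beyond the scatter above it. The steps of a 10-fold lower number from compound 1 to compound 3 (1.00 log units; beyond the scatter) and a 10-fold lower number from compound 2 to compound 3 (1.00 log units; beyond the scatter) both show that the small methyl is favoured over an aromatic group, whereas no change at the digits printed from compound 1 to compound 2 (within the scatter) shows that fluoro in place of hydrogen on that aromatic ring makes no difference.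

Compound 4 `O=C1NC(c2ccccc2)(c2ccccc2)C(=O)N1CN1CCN(c2cccc(C(F)(F)F)c2)CC1` reverses this move: 3-(trifluoromethyl)phenyl in place of methyl on an amine nitrogen in a ring. Because both a 10-fold lower number from compound 1 to compound 3 (1.00 log units; beyond the scatter) and a 10-fold lower number from compound 2 to compound 3 (1.00 log units; beyond the scatter) ran in the opposite direction with the same size, a return to the level of the aryl compounds is expected. Compound 4 is therefore estimated at 100 mg/kg, with a range from 30 mg/kg to 300 mg/kg. That estimate corresponds to an expected step of a 10-fold higher number from compound 3 to compound 4 (1.00 log units; beyond the scatter).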

Compound 4, minimum effective dose: 100 mg/kg
For compound 4 middle estimate and measured number coincide at the digits printed; low and high end bracket the measured number.
By their numbers in this assay, from the lowest: compound 3; then compounds 1, 2 and 4 (each within the scatter of the next).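

In this assay the step of a 10-fold higher number from compound 3 to compound 4 (1.00 log units; beyond the scatter) shows that the higher number seen on leaving methyl is not tied to phenyl or 4-fluorophenyl but also appears with 3-(trifluoromethyl)phenyl on this ring nitrogen. The steps of no change at the digits printed from compound 1 to compound 4 (within the scatter) and no change at the digits printed from compound 2 to compound 4 (within the scatter) add that a trifluoromethyl on the aromatic ring, like the fluoro before it, leaves the number where it was. Across these three aryl compounds, then, what the aromatic ring carries makes no readable difference, and only the choice of methyl or an aromatic ring on this nitrogen does.

Nothing given here explains this pattern. Open, going by these compounds, is whether an ethyl, a longer chain, a benzyl group or a plain hydrogen on this nitrogen would stay level with compound 3 at 10 mg/kg or move toward the aryl compounds.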